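Shifting the Methoxy on a Naphthyl Substituent

The source may report more compounds than this note shows. Statements on the series, on what has been measured and on what is new or still open speak of the compounds shown alone.

Compound 1 `COc1cc(N2C(N)=C(C#N)C(c3ccc([N+](=O)[O-])cc3)C3=C2CC(C)(C)CC3=O)cc(OC)c1OC`: 50%
Compound 2 `COc1cc(N2C(N)=C(C#N)C(c3c(OC)ccc4ccccc34)C3=C2CC(C)(C)CC3=O)cc(OC)c1OC`: 5%

Of the compounds shown here, two have been measured in a functional assay on Ehrlich cells (Mus musculus) for cytotoxicity, tested at 25 ug/mL; a lower number here means a weaker effect, a higher number a stronger effect of the compound at the concentration tested. Compound 1 gives 50%, while compound 2 gives 5%. Within the data shown here, compound 2 stands lowest of the two numbers; its nearest neighbour is compound 1, and the single measured step, a number 45 percentage points lower from compound 1 to compound 2 (beyond the scatter), is a large one.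

The unmeasured compound 3 `COc1cc(N2C(N)=C(C#N)C(c3ccc(OC)c4ccccc34)C3=C2CC(C)(C)CC3=O)cc(OC)c1OC` differs from compound 2 in one place: 4-methoxynaphthalen-1-yl in place of 2-methoxynaphthalen-1-yl on a saturated ring carbon. The two have the same atoms, joined differently. Among the measured compounds shown here, the only measured step exchanged a 4-nitrophenyl for a 2-methoxynaphthalen-1-yl on the saturated ring carbon; it does not compare a 4-methoxynaphthalen-1-yl with a 2-methoxynaphthalen-1-yl, so no measured step bears directly on the change to compound 3. Both compound 2 and compound 3 carry a methoxynaphthalenyl group at that carbon, and there is nothing in the data to point to a direction.

Compound 3 is therefore expected to show a step of a number 3 percentage points higher from compound 2 to compound 3 (within the scatter) in this assay, none beyond the scatter. The activity of compound 3 is estimated at 8%, in the range from 0% to 30%.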

Compound 3, a percentage reported as activity, at one concentration (the size of the read-out at that concentration, not a potency): 30%
The estimate for compound 3 lay 22 percentage points below the measured number; the measured number falls inside the stated range.
By their numbers in this assay, from the lowest: compound 2; then compound 3; then compound 1.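

In this assay, moving the methoxy within the methoxynaphthalen-1-yl group on the saturated ring carbon gives a number 25 percentage points higher from compound 2 to compound 3 (beyond the scatter), so two groups with the same atoms and the same counted features do not behave alike at this position. The very low number of compound 2 therefore does not hold for both methoxynaphthalen-1-yl groups shown here, although the 4-methoxynaphthalen-1-yl group still does not match the 4-nitrophenyl group, with a number 20 percentage points lower from compound 1 to compound 3 (beyond the scatter). No measurement at hand explains why the place of the methoxy matters here.

The compounds shown leave open how much of the gap to compound 1 belongs to the nitro group and how much to the second aromatic ring, a question that a 4-methoxyphenyl group or an unsubstituted naphthalen-1-yl group on the same carbon would help to separate. They also leave open whether the trend set by the two methoxy placements extends to a 4-hydroxynaphthalen-1-yl group or to a longer ether such as 4-ethoxynaphthalen-1-yl, and the single tested concentration says nothing about potency.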